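The source may hold more compounds than are shown below. What is called first, only, known or untested is meant among the compounds shown, and "the series" means these compounds.

In an assay for inhibition of solute carrier family 22 member 12 (Homo sapiens), read by scintillation counting, with a stated time of 60 min, tested at 50 uM (on this read-out higher numbers stand for more inhibition at the one concentration tested (going by the name of the read-out) and lower numbers for less inhibition), the measured compounds stand as follows:
compound 1 `CCc1oc2ccc(OC)cc2c1C(=O)c1ccc(OC)cc1` gives 24.3%
compound 2 `CCc1cc2c(C(=O)c3ccc(OC)cc3)ccc(OC)c2o1` gives 7.4%
compound 3 `CCc1cc2c(C(=O)c3ccc(OC)cc3)ccc(O)c2o1` gives 0.8%

Compound 3 holds the lowest of the three numbers. Its nearest neighbour is compound 2, whose number is within the scatter of it, so the two cannot be ordered; compound 1 is the furthest away, and that gap lies beyond the scatter. Among the measured compounds shown here, the only one-point step among the measured compounds, hydrogen in place of methyl on an oxygen on an aromatic ring, is a number 6.6 percentage points lower from compound 2 to compound 3 (within the scatter) and lies within the scatter.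

Compound 4 `CCc1cc2c(C(=O)c3ccc(OC)cc3)cc(Br)c(O)c2o1` is the next member. Its difference from compound 3 is bromo in place of hydrogen on an aromatic carbon. No measured step in this series involves a bromo group or any substitution on an aromatic carbon, so none of the steps shown bears on this change; the single step that is known, from compound 2 to compound 3, concerns a different place and was within the scatter. With nothing to point either way, the expectation for compound 4 in this assay is a step of no more than the scatter, a number 4.2 percentage points higher from compound 3 to compound 4 (within the scatter), from the low number of compound 3. The estimate for compound 4 is therefore 5%, with a range from -8% to 20%.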

Compound 4, a percentage reported as inhibition, at one concentration (the size of the read-out at that concentration, not a potency): 99.3%
The estimate for compound 4 lay 94.3 percentage points below the measured number; the whole stated range lies below it.
By their numbers in this assay, from the lowest: compounds 3 and 2 (each within the scatter of the next); then compound 1; then compound 4.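

In this assay, bromo in place of hydrogen on an aromatic carbon, ortho to a hydroxy group and para to a fused ring, gives a number 98.5 percentage points higher from compound 3 to compound 4 (beyond the scatter), so a change of one heavy atom at this position can move the read-out by a large amount. Among the compounds shown here, the only earlier step, at the oxygen on the same ring, was a number 6.6 percentage points lower from compound 2 to compound 3 (within the scatter), so compound 4 is the first evidence that the series responds strongly to a single change and that this aromatic carbon is a sensitive place. No measurement shown here explains the size of this step.

Going by these compounds, it remains open whether the step is specific to bromo or would also appear with chloro, iodo or a methyl group on this carbon, and whether bromo would have the same effect with methoxy in place of the hydroxy group. The read-out is a percentage at one concentration, so the compounds shown also leave open how compound 4 would rank on a full concentration-response measurement.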